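From an arylthio group to a bare amino group

This account rests on a few compounds, and the source may have more. Where it says the series, first, only, none or still open, it means among the compounds named here.

Compound 3 `Cc1cc(Sc2ccncc2)c(S(C)(=O)=O)cc1C(=O)N=C(N)N` gives 13 nM in a functional assay for inhibition of sodium/hydrogen exchanger (Oryctolagus cuniculus); on this read-out higher numbers stand for weaker inhibition and lower numbers for stronger inhibition. Compound 1 `Cc1cc(-c2ccco2)c(S(C)(=O)=O)cc1C(=O)N=C(N)N` gives 16 nM and compound 2 `Cc1cc(Sc2ccc(Cl)cc2)c(S(C)(=O)=O)cc1C(=O)N=C(N)N` gives 19 nM; all three values lie within the scatter of one another, so compound 3 holds the lowest of three numbers that cannot be told apart. The measured steps are a 1.2-fold lower number from compound 1 to compound 3 (0.09 log units; within the scatter), a 1.5-fold lower number from compound 2 to compound 3 (0.16 log units; within the scatter) and a 1.2-fold higher number from compound 1 to compound 2 (0.07 log units; within the scatter). Compound 4 `Cc1cc(N)c(S(C)(=O)=O)cc1C(=O)N=C(N)N` is the unmeasured candidate; (amino in place of (pyridin-4-yl)sulfanyl on an aromatic carbon). The change sits ortho to a methylsulfonyl group and meta to a methyl group on the shared core. Each measured step swaps one ring-bearing group for another at this carbon and stays within the scatter, so among compounds 1, 2 and 3 the choice of ring makes no visible difference; none of these steps removes the ring altogether, which is what compound 4 does. Among the compounds with values here, there is no precedent for such a replacement, so the expectation rests on the tolerance seen among compounds 1 to 3 with added uncertainty. The author expects a modest step of a 2.3-fold higher number from compound 3 to compound 4 (0.36 log units; beyond the scatter) toward a weaker number. Compound 4 is therefore estimated at 30 nM, with a range of 8 nM to 120 nM.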

Compound 4, half-maximal inhibitory concentration: 16 nM
The estimate for compound 4 lay 1.9-fold (0.27 log units) above the measured number, and the stated range covers the measured number.
By their numbers in this assay, from the lowest: compounds 3, 1, 4 and 2 (each within the scatter of the next).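

In this assay the step of a 1.2-fold higher number from compound 3 to compound 4 (0.09 log units; within the scatter) replaces (pyridin-4-yl)sulfanyl with amino, the step of a 1.2-fold lower number from compound 2 to compound 4 (0.07 log units; within the scatter) replaces (4-chlorophenyl)sulfanyl with amino, and the step of no change at the digits printed from compound 1 to compound 4 (within the scatter) replaces furan-2-yl with amino, and none of the three can be told from no change. The earlier steps shown here only exchanged one ring-bearing group for another, whereas these show that on this core, and on this read-out, a ring at this aromatic carbon can be dropped entirely in favour of a group with no ring, so neither the ring nor the sulfur that carries it in compound 2 and compound 3 is required for a number in this range. Nothing in the information at hand accounts for this tolerance.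

The compounds shown leave open whether it extends to a bare hydrogen, a hydroxyl or a carboxylic acid at this carbon, and whether methylamino or dimethylamino would behave as amino does. They also leave open whether amino is tolerated equally when the neighbouring methylsulfonyl group is exchanged for an ethylsulfonyl or a trifluoromethyl group, as all four compounds carry methylsulfonyl.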